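From 3-aminopropoxy to (piperidin-4-yl)oxy: working notes

The compounds below may be only part of what the source reports. "The series", "measured", "known", "first", "only" and "open" are said of these compounds alone.

Measured in a functional assay on MCF7 cells (Homo sapiens) for inhibition, read by MTT assay, with a stated time of 72 h; a higher number here means a weaker inhibitor, a lower number a stronger inhibitor (all three values are limits, not numbers):
Compound 1 `CC(C)[C@H](NC(=O)c1cc(Cl)ccc1OCCN)C(=O)Nc1ccc([N+](=O)[O-])cc1Cl` gives > 10000 nM
Compound 2 `CC(C)[C@H](NC(=O)c1cc(Cl)ccc1OCCCNC(=O)OC(C)(C)C)C(=O)Nc1ccc([N+](=O)[O-])cc1Cl` gives > 10000 nM
Compound 3 `CC(C)[C@H](NC(=O)c1cc(Cl)ccc1OCCCN)C(=O)Nc1ccc([N+](=O)[O-])cc1Cl` gives > 10000 nM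

Compound 3 has no number of its own in this assay and stands only at the limit > 10000 nM in this series. The other two compounds share that position, as the limit of > 10000 nM in this assay, at which 3 of the 3 values shown sit, shows.

The next change leads to compound 4 `CC(C)[C@H](NC(=O)c1cc(Cl)ccc1OC1CCNCC1)C(=O)Nc1ccc([N+](=O)[O-])cc1Cl` and puts piperidin-4-yl in place of 3-aminopropyl on an oxygen on an aromatic ring here.

Three measured steps alter the same group on that oxygen. They are a step that the two limits leave unreadable from compound 1 to compound 3, then a step that the two limits leave unreadable from compound 1 to compound 2 and finally a step that the two limits leave unreadable from compound 2 to compound 3 in turn. None of them has a size that can be read, so they give no direction. None of compounds 1, 2 and 3 has left the limit.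

With compound 3 given as the limit > 10000 nM, no step beyond the scatter is expected for this change. The expected step is a step that the limit leaves unreadable from compound 3 to compound 4 in this assay by this estimate. The estimate for compound 4 is 15000 nM with an expected range from 8000 nM to 40000 nM and a report as a limit is the likeliest outcome.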

Compound 4, half-maximal inhibitory concentration: > 10000 nM
Compound 4: a limit, no number; the forecaster's own chance of this, stated with the estimate: 88%; the middle value is on the limit's open side.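

No new step can be read: compound 4, like compounds 1, 2 and 3, stands only at a limit in this assay, and its steps from those three compounds cannot be read. The compounds shown leave open how the groups on that oxygen compare, with every value resting at one place: the limit of > 10000 nM in this assay, at which 4 of the 4 values shown sit.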